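The source may hold more compounds than are shown below. What is called first, only, known or untested is meant among the compounds shown, and "the series" means these compounds.

Of the compounds shown here, two of the same core have been measured in an assay on isolated protein for inhibition of Alpha-2B adrenergic receptor (Homo sapiens); a lower number here means a stronger inhibitor, a higher number a weaker inhibitor. Compound 1, `O=C1c2ccccc2C(=O)N1CC#Cc1ccc2c(c1)C=C([N+](=O)[O-])C(C(F)(F)F)O2`, carries a phthalimide-type group on its side chain, and in this assay compound 1 gives 4700 nM. Compound 2, `CC(=O)NCC#Cc1ccc2c(c1)C=C([N+](=O)[O-])C(C(F)(F)F)O2`, carries an acetamidomethyl group on the same triple-bonded carbon, and in this assay compound 2 gives 6700 nM. Compound 2 thus gives the higher of the two numbers, but the gap to compound 1 is small enough to fall inside the usual scatter of repeated measurements, so the two cannot be told apart.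

Compound 3, `O=C(O)c1ccc(C#Cc2ccc3c(c2)C=C([N+](=O)[O-])C(C(F)(F)F)O3)cc1`, has not yet been measured. Its difference from compound 2 is 4-carboxyphenyl in place of acetamidomethyl on a triple-bonded carbon. For the measured compounds named here, no step between measured compounds of this kind is known, so any expectation rests on the two values shown. Since both measured compounds give weak inhibition in this assay, compound 3 is expected to stay in that region, and the step from compound 2 to compound 3 is estimated as a 1.3-fold lower number from compound 2 to compound 3 (0.13 log units; within the scatter), a change not clearly beyond the scatter. Compound 3 is therefore estimated to give 5000 nM in this assay, with a plausible range from 1500 nM to 16000 nM.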

Compound 3, inhibition constant: 1000 nM
Compound 3: the middle estimate sits 5.0-fold (0.70 log units) above what was measured, outside the stated range (below it).
By their numbers in this assay, from the lowest: compound 3; then compounds 1 and 2 (each within the scatter of the next).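

In this assay, the group on this triple-bonded carbon can clearly affect the result: 4-carboxyphenyl in place of acetamidomethyl gives a 6.7-fold lower number from compound 2 to compound 3 (0.83 log units; beyond the scatter). For the compounds shown here, compounds 1 and 2 lie within the scatter of each other, so they gave no clear sign of this, while the new step is the first one here that can be told apart from repeated-measurement noise. Nothing shown explains why this change goes with stronger inhibition.

The change brings in an aromatic ring and a carboxylic acid together, so these compounds cannot separate the contribution of one from that of the other. On these data alone, it remains open how a plain phenyl group, a methyl ester of the acid, or a carboxylic acid on a short open chain with no ring would compare on the same triple-bonded carbon.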